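This account rests on a few compounds, and the source may have more. Where it says the series, first, only, none or still open, it means among the compounds named here.

Measured so far in a functional assay on PC-3 cells (Homo sapiens) for antiproliferative activity, read by CCK-8 assay, with a stated time of 6 days; a higher number here means a weaker inhibitor, a lower number a stronger inhibitor:

Compound 1 `CCN(c1ccc(C#N)c(Cl)c1)c1cc(-c2cccs2)ccc1C`: > 30000 nM, a limit of the assay and not a number
Compound 2 `CCN(c1ccc(C#N)c(Cl)c1)c1cc(-c2c[nH]nc2C)ccc1C`: 9030 nM

For the measured compounds named here, compound 2 gives 9030 nM, the only true number so far, so there is no series of values to rank it in. Compound 3 `CCN(c1ccc(C#N)c(Cl)c1)c1cc(-n2cccn2)ccc1C` differs from it in one place: 1H-pyrazol-1-yl in place of 3-methyl-1H-pyrazol-4-yl on an aromatic carbon. In words, this puts 1H-pyrazol-1-yl in place of 3-methyl-1H-pyrazol-4-yl on an aromatic carbon.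

Going by the values given here, one measured step bears on this same place: an at least 3.3-fold lower number from compound 1 to compound 2 (0.52 log units; beyond the scatter). As far as these compounds go, it rests on (the limit of > 30000 nM in this assay, at which 1 of the 2 values shown sits), so its true size stays open. Compound 3 gives up the group that entered in that step, so a modest move towards a higher number is expected, with no certainty that it will be large.

The expected change is a 2.2-fold higher number from compound 2 to compound 3 (0.35 log units; beyond the scatter). For compound 3 the estimate is 20000 nM, with an expected range of 8000 nM to 30000 nM.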

Compound 3, half-maximal inhibitory concentration: 15700 nM
Compound 3: middle estimate off by 1.3-fold (0.11 log units), on the high side, and the stated range covers the measured number.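

In this assay the new result gives a 1.7-fold higher number from compound 2 to compound 3 (0.24 log units; within the scatter), so this pair cannot be told apart at this position, even though 3-methyl-1H-pyrazol-4-yl carries 1 hydrogen-bond donor and 1H-pyrazol-1-yl carries 0. Compound 3 therefore shows that a hydrogen-bond donor on the ring is not required for a number in this range. The comparison with the thiophen-2-yl group gives only an at least 1.9-fold lower number from compound 1 to compound 3 (0.28 log units; that floor lies within the scatter), which does not establish a real gap, and its true size stays open: the limit of > 30000 nM in this assay, at which 1 of the 3 values shown sits.

As far as these compounds go, compound 3 removes the methyl group and moves the ring's point of attachment in one change, so the share of each remains open. Also open, from the compounds shown here alone, is whether an amine or a carboxylic acid on this aromatic carbon would give a number beyond the scatter from compound 2.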